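The compounds below may be only part of what the source reports. "The series", "measured", "known", "first", "only" and "open" are said of these compounds alone.

Compound 1 `FC(F)(F)Oc1ccc(Nc2cc(-c3cccc4[nH]ccc34)ncn2)cc1` gives 3790 nM in an ADME assay on BaF3 cells (Mus musculus) for cytotoxicity; on this read-out higher numbers stand for an effect only at larger amounts of compound and lower numbers for an effect already at smaller amounts.
Compound 2 `FC(F)(F)Oc1ccc(Nc2cc(-c3cn[nH]c3)ncn2)cc1` gives > 10000 nM in this assay, which is a limit of the assay and not a number.

Compound 2 therefore stands at the least toxic end of what has been measured, sitting at the limit of > 10000 nM in this assay, at which 1 of the 2 values shown sits. Among the measured compounds shown here, the only measured step, an at least 2.6-fold higher number from compound 1 to compound 2 (0.42 log units; beyond the scatter), shows that swapping the larger bicyclic group for the small five-membered ring pushed the number up beyond the scatter. Compound 3 `FC(F)(F)Oc1ccc(Nc2cc(-c3ccncc3)ncn2)cc1` differs from compound 2 by pyridin-4-yl in place of 1H-pyrazol-4-yl on an aromatic carbon. For the measured compounds named here, no measured step covers a six-membered ring at this position, so the expectation rests on how close both known values lie to the limit. The change from compound 2 to compound 3 is expected to be an at least 1.4-fold lower number from compound 2 to compound 3 (0.15 log units; that floor lies within the scatter), a small step downward or none beyond the scatter. Compound 3 is thus estimated at 7000 nM, with a range from 2500 nM to 10000 nM.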

Compound 3, half-maximal effective concentration: > 10000 nM
Compound 3: no number, only a limit; the forecaster's own chance of this, stated with the estimate: 50%; middle value at least 1.4-fold (0.15 log units) away from the limit.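

In this assay, pyridin-4-yl in place of 1H-indol-4-yl gives an at least 2.6-fold higher number from compound 1 to compound 3 (0.42 log units; beyond the scatter), so the rise seen with 1H-pyrazol-4-yl is not confined to that one ring. Pyridin-4-yl has a six-membered ring and 0 hydrogen-bond donors, while 1H-pyrazol-4-yl has a five-membered ring and 1 hydrogen-bond donor, so neither that ring size nor that donor is required to reach the same end of the scale: the limit of > 10000 nM in this assay, at which 2 of the 3 values shown sit. The step between compound 2 and compound 3 cannot be read, so the two rings cannot be ranked against each other.

Going by these compounds, it remains open whether a plain phenyl ring, with no ring nitrogen, or a small amine at this position would also reach this limit. On these data alone, how far compound 2 and compound 3 lie past the limit also remains open.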